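This account rests on a few compounds, and the source may have more. Where it says the series, first, only, none or still open, it means among the compounds named here.

In a functional assay on HeLa cells (Homo sapiens) for inhibition, read by MTT assay, with a stated time of 48 h (a higher number here means a weaker inhibitor of growth, a lower number a stronger inhibitor of growth), two members of the series have been measured on the shared core. Compound 1 `Cn1cc(C2CC(c3ccccc3)=NN2C(=O)c2cccnc2)c2cc(Br)ccc21` gives 1730 nM, and compound 2 `Cn1cc(C2CC(c3ccc(Cl)cc3)=NN2C(=O)c2cccnc2)c2cc(Br)ccc21` gives 5200 nM, the higher of the two numbers and so the weaker growth inhibitor. Compound 3 `Cn1cc(C2CC(c3ccc(Br)cc3)=NN2C(=O)c2cccnc2)c2cc(Br)ccc21` is still unmeasured. It differs from compound 2 by one change: bromo in place of chloro on an aromatic carbon. In words, this is bromo in place of chloro on an aromatic carbon, or 4-chlorophenyl to 4-bromophenyl. Among the compounds with values here, only one measured step bears on this place: chloro in place of hydrogen gave a 3.0-fold higher number from compound 1 to compound 2 (0.48 log units; beyond the scatter), a modest step. Within the data shown here, that step starts from hydrogen, and no measured pair yet exchanges one halogen for another, so the evidence is thin. Among the measured compounds shown here, with the step of a 3.0-fold higher number from compound 1 to compound 2 (0.48 log units; beyond the scatter) as the only guide and a halogen already present in compound 2, no shift beyond the scatter is expected in this assay, in either direction. The expected change is a 1.0-fold lower number from compound 2 to compound 3 (0.02 log units; within the scatter). Compound 3 is estimated at 5000 nM, with an expected range of 2500 nM to 10000 nM.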

Compound 3, concentration for 50% growth inhibition: > 10000 nM
Compound 3: a limit, no number; the forecaster's own chance of this, stated with the estimate: 3%; middle value at least 2.0-fold (0.30 log units) away from the limit.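

In this assay compound 3 gives > 10000 nM, which is a limit of the assay and not a number, and the series now has its first reading without an upper end: the limit of > 10000 nM in this assay, at which 1 of the 3 values shown sits. Replacing hydrogen with bromo at this place, on an aromatic carbon para to a large group, gives an at least 5.7-fold higher number from compound 1 to compound 3 (0.76 log units; beyond the scatter), so this second halogen also moves the number upward from compound 1 beyond the scatter, and the hydrogen of compound 1 gives the lowest number of the three. The exchange of one halogen for the other gives an at least 1.9-fold higher number from compound 2 to compound 3 (0.28 log units; that floor lies within the scatter), a floor that does not by itself separate bromo from chloro, although the true step may be larger.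

On these data alone, the size of the step from compound 2 to compound 3 stays unknown, as does how far compound 3 lies past its limit. Also open is whether fluoro, methoxy, an amine or a carboxylic acid at this place would keep the number near that of compound 1 or raise it as both halogens do, and the compounds shown give no cause for the rise.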